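The source may report more compounds than this note shows. Statements on the series, on what has been measured and on what is new or still open speak of the compounds shown alone.

Working notes on a short amide series in an assay on isolated protein for inhibition of thyroid hormone receptor beta (Homo sapiens), read by fluorescence polarization; on this read-out lower numbers stand for stronger inhibition and higher numbers for weaker inhibition. Compound 1 `CS(=O)(=O)c1ccc(C(=O)NCC(=O)N(Cc2ccccc2)Cc2ccccc2)cc1[N+](=O)[O-]` carries the amide hydrogen and in this assay gives 3600 nM. Compound 2 `CN(CC(=O)N(Cc1ccccc1)Cc1ccccc1)C(=O)c1ccc(S(C)(=O)=O)c([N+](=O)[O-])c1` is its counterpart with a methyl on the amide-type nitrogen. In this assay compound 2 returns only the limit > 60000 nM. Compound 3 `CN(CC(=O)N1CCc2ccccc2C1)C(=O)c1ccc(S(C)(=O)=O)c([N+](=O)[O-])c1` also carries the methyl on the amide-type nitrogen, and in this assay compound 3 likewise returns only the limit > 60000 nM. The difference between the core of compound 2 and the core of compound 3 is not broken down here. Compound 4 `CS(=O)(=O)c1ccc(C(=O)NCC(=O)N2CCc3ccccc3C2)cc1[N+](=O)[O-]` has not yet been measured in this assay.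

The measured step of an at least 16-fold lower number from compound 2 to compound 1 (1.22 log units; beyond the scatter) results from the change (hydrogen in place of methyl on an amide-type nitrogen). The same kind of change, (hydrogen in place of methyl on an amide-type nitrogen), separates compound 3 from compound 4, and the surroundings of the place read the same word for word in both cases. Because two of the three values sit at the limit of > 60000 nM in this assay, at which 2 of the 3 values shown sit, only a lower bound of the measured step is known, and the true gain from compound 2 to compound 1 may be larger than the bound.

Expectation: the step from compound 3 to compound 4 in this assay is estimated at an at least 15-fold lower number from compound 3 to compound 4 (1.17 log units; beyond the scatter), resting on the step of an at least 16-fold lower number from compound 2 to compound 1 (1.22 log units; beyond the scatter) seen for the same kind of change. Compound 4 is accordingly expected near 4000 nM, with a likely span from 1200 nM to 25000 nM, and some chance that only a limit is reported.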

Compound 4, half-maximal inhibitory concentration: 46000 nM
Compound 4: the middle estimate sits 12-fold (1.06 log units) below what was measured, outside the stated range (above it).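

In this assay, hydrogen in place of methyl on the amide-type nitrogen of the core of compound 3 gives an at least 1.3-fold lower number from compound 3 to compound 4 (0.11 log units; that floor lies within the scatter), so this core offers only a floor inside the scatter and no confirmed gain from the change. Compound 3 is known only through a limit, and that limit, not a measured number, sets the floor; the true size of the step on this core could be small or much larger, and the same uncertainty applies to the first core: the limit of > 60000 nM in this assay, at which 2 of the 4 values shown sit. The result therefore neither shows that the large step carries over in full nor shows that it fails to carry over, and the comparison of the two cores stays unresolved: the same change on two cores in this assay, an at least 16-fold lower number (1.22 log units; beyond the scatter) from compound 2 to compound 1 and an at least 1.3-fold lower number (0.11 log units; that floor lies within the scatter) from compound 3 to compound 4; the limit leaves it open whether they differ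

The compounds shown leave open how this nitrogen behaves with an ethyl group or a longer chain in place of the methyl, since only hydrogen and methyl appear there. They also leave open whether the amide hydrogen still goes with a measurable number in this assay when the nitro group gives way to a nitrile or a carboxylic acid.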